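From trifluoromethoxy to difluoromethoxy

The source may hold more compounds than are shown below. What is called first, only, known or untested is meant among the compounds shown, and "the series" means these compounds.

In an ADME assay on a cell-free system (plasma, Homo sapiens) for protein binding, compound 1 `CNc1nccc(N2CC[C@H](NC(=O)Nc3ccc(OC)cc3)C2)n1` gives 80% and compound 2 `CNc1nccc(N2CC[C@H](NC(=O)Nc3ccc(OC(F)(F)F)cc3)C2)n1` gives 97.7% on the same core. Compound 2 therefore has the lower unbound fraction of the two. Within the data shown here, the only measured step is an 8.7-fold lower unbound fraction from compound 1 to compound 2 (0.94 log units; beyond the scatter) and it comes with trifluoromethyl in place of methyl on an oxygen on an aromatic ring.

Compound 3 `CNc1nccc(N2CC[C@H](NC(=O)Nc3ccc(OC(F)F)cc3)C2)n1` differs from compound 2 (hydrogen in place of fluoro on a saturated chain carbon bound to two fluorine atoms and an oxygen on an aromatic ring) by hydrogen in place of fluoro on a saturated chain carbon bound to two fluorine atoms and an oxygen on an aromatic ring, turning trifluoromethoxy into difluoromethoxy. By fluorine content, its difluoromethyl group falls between the methyl of compound 1 and the trifluoromethyl of compound 2. The measured step of an 8.7-fold lower unbound fraction from compound 1 to compound 2 (0.94 log units; beyond the scatter) thus serves as the outer bound for the change, which should run in the opposite direction. Among the measured compounds shown here, no measured compound carries difluoromethyl, so the size of the return remains uncertain. The expected change is a 3.0-fold higher unbound fraction from compound 2 to compound 3 (0.48 log units; beyond the scatter) as a partial return along that measured step. For compound 3 the estimate is 93% with an expected range from 87% to 97% in this measurement.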

Compound 3, plasma protein binding: 93.8%
Compound 3: middle estimate off by 1.1-fold (0.05 log units) (unbound fraction), on the high side; the measured number falls inside the stated range.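

With compound 3, the position now gives three readings on the shared core in this assay, and losing a single fluorine is enough to move the result: the change from trifluoromethoxy to difluoromethoxy gives a 2.7-fold higher unbound fraction from compound 2 to compound 3 (0.43 log units; beyond the scatter). The difluoromethoxy group does not return the unbound fraction to the level seen with methoxy, since swapping methyl for difluoromethyl on the oxygen still gives a 3.2-fold lower unbound fraction from compound 1 to compound 3 (0.51 log units; beyond the scatter). The unbound fraction therefore falls in step with fluorine count across these three compounds, none goes against that order, and no available evidence bears on what lies behind it.

From the compounds shown here alone, three compounds on one core make a short series, and it remains open where a monofluoromethyl group on the same oxygen would fall, which would show whether each fluorine contributes a similar step. Going by these compounds, it is also open whether an ethyl group on that oxygen, or a chlorine directly on the aromatic ring in place of the whole alkoxy group, would fit the same order, and whether the order carries over to a different core.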